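The compounds below may be only part of what the source reports. "The series", "measured", "known", "first", "only" and "open" are said of these compounds alone.

Compound 1 `COc1ccccc1N1C(=O)/C(=C/c2ccc(OCc3ccc(C(=O)O)cc3)cc2)SC1=S` carries 2-methoxyphenyl on the amide-type nitrogen of its five-membered ring, and in an assay on isolated protein for inhibition of Apoptosis regulator Bcl-2 (Homo sapiens), read by fluorescence polarization (a higher number here means a weaker inhibitor, a lower number a stronger inhibitor), compound 1 gives 2000 nM. Compound 2 `CC(=O)c1ccc(N2C(=O)/C(=C/c3ccc(OCc4ccc(C(=O)O)cc4)cc3)SC2=S)cc1` carries 4-acetylphenyl in that place. In this assay compound 2 reaches only the limit > 10000 nM, not a number. Compound 3 `O=C(O)c1ccc(COc2ccc(/C=C3\SC(=S)N(c4cccc(C(F)(F)F)c4)C3=O)cc2)cc1` carries 3-(trifluoromethyl)phenyl in that place. In this assay compound 3 likewise gives only the limit > 10000 nM, so compound 3 stands where a number is no longer read. The two readable steps, an at least 5.0-fold higher number from compound 1 to compound 2 (0.69 log units; beyond the scatter) and an at least 5.0-fold higher number from compound 1 to compound 3 (0.69 log units; beyond the scatter), point the same way: exchanging 2-methoxyphenyl for 4-acetylphenyl or 3-(trifluoromethyl)phenyl weakened inhibition beyond the scatter, and because the limit of > 10000 nM in this assay, at which 2 of the 3 values shown sit, holds both of them, the step that the two limits leave unreadable from compound 2 to compound 3 cannot be sized. Compound 4 `O=C(O)c1ccc(COc2ccc(/C=C3\SC(=S)N(c4ccc(Br)cc4)C3=O)cc2)cc1` is the next variation: 4-bromophenyl in place of 3-(trifluoromethyl)phenyl on an amide-type nitrogen in a ring. Since compound 3 already sits at the limit, the step of an at least 1.1-fold lower number from compound 3 to compound 4 (0.04 log units; that floor lies within the scatter) is expected to be small or not readable, with no direction established. Compound 4 is therefore estimated at 9000 nM, within a range from 2500 nM to 30000 nM, most likely reported again only as a limit.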

Compound 4, inhibition constant: 610 nM
For compound 4 the middle estimate is 15-fold (1.17 log units) above the measured one; measured number outside the range, below it.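

Until now every exchange of 2-methoxyphenyl on this nitrogen had weakened inhibition, but 4-bromophenyl goes the other way, with a 3.3-fold lower number from compound 1 to compound 4 (0.52 log units; beyond the scatter). The group on this ring nitrogen can therefore swing binding widely, as an at least 16-fold lower number from compound 3 to compound 4 (1.21 log units; beyond the scatter) and an at least 16-fold lower number from compound 2 to compound 4 (1.21 log units; beyond the scatter) both show, and the latter step, bromo in place of acetyl on an aromatic carbon, means that the ring position alone does not decide the outcome. These two steps are floors rather than full sizes, because compound 2 and compound 3 each gave only a limit: the limit of > 10000 nM in this assay, at which 2 of the 4 values shown sit.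

Compound 3 and compound 4 differ in both the group and its ring position, so a 3-bromophenyl would be needed to separate the two. From the compounds shown here alone, whether bromine itself matters stays open too, and 4-chlorophenyl or unsubstituted phenyl would test that.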